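Acid to Amide on a Weak FFAR1 Partial Agonist

A few compounds are considered here, and "the series" means these few. Any claim that something is new, unique, unknown or untested is made for them only; others in the source may bear on it.

Of the compounds shown here, two have been measured in a functional assay on CHO cells for agonist activity at Free fatty acid receptor 1 (Homo sapiens), read by a luciferase reporter; on this read-out higher numbers stand for larger maximal responses and lower numbers for smaller maximal responses. Compound 1 `Cc1nc(-c2ccc(C(F)(F)F)cc2)sc1CNc1ccc(CC(=O)O)cc1` gives 18%, the lower of the two numbers. Compound 2 `O=C(O)/C=C/c1ccc(NCc2cccc(Oc3ccccc3)c2)cc1` gives 76% in this assay, a gap beyond the usual scatter; the two share no single-point change, so their values simply stand side by side. Compound 3 `Cc1nc(-c2ccc(C(F)(F)F)cc2)sc1CNc1ccc(CCC(=O)NC(C)C)cc1` has not yet been measured in this assay. It differs from compound 1 in one place: (isopropylcarbamoyl)methyl in place of carboxy on a saturated chain carbon bound to an aromatic carbon. Going by the values given here, no measured pair shows an exchange of this kind, so there is no precedent to lean on. Compound 1 gives only 18%, leaving little room beneath it. The expected step of a number 10 percentage points lower from compound 1 to compound 3 (within the scatter) is therefore small and downward, if anything, and may well stay within the scatter. In this assay compound 3 is estimated at 8%, within a range from 0% to 25%.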

Compound 3, largest response reached (reported as percent of maximum), in percent of the reference or control that the assay uses: 84%
Beside the measured number, compound 3's estimate is 76 percentage points below it; the whole stated range lies below it.
By their numbers in this assay, from the lowest: compound 1; then compounds 2 and 3 (each within the scatter of the next).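

In this assay, replacing carboxy with (isopropylcarbamoyl)methyl on a saturated chain carbon bound to an aromatic carbon gives a number 66 percentage points higher from compound 1 to compound 3 (beyond the scatter), so a large maximal response on the core of compound 1 does not require carboxy at this place. The two groups match in their counts of hydrogen-bond donors and acceptors, and neither carries a net charge, but the entering group has more heavy atoms and includes a nitrogen. Nothing available explains the rise in response.

This single exchange changes chain length and end group together, so the contributions of the longer chain, the amide and the isopropyl group cannot be separated. A 2-carboxyethyl group, an unsubstituted carbamoylmethyl group or a cyclopropyl amide at this place would help to tell them apart.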